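Compound 1 and the Chain with One Double Bond

The source may report more compounds than this note shows. Statements on the series, on what has been measured and on what is new or still open speak of the compounds shown alone.

Of the compounds shown here, three have been measured in a functional assay on HT-29 cells (Homo sapiens) for cytotoxicity, read by XTT assay, with a stated time of 72 h; a lower number here means a stronger inhibitor, a higher number a weaker inhibitor.
Compound 1 `CCCCCCCCCCCCCCCCCCc1c(O)cc(O)c(C(C)=O)c1O` gives 28000 nM.
Compound 2 `CCCCCCCC/C=C\CCCCCCCCOc1cc(O)c(C(C)=O)c(OCCCCCCCC/C=C\CCCCCCCC)c1` reaches only a limit of this assay, > 100000 nM.
Compound 3 `C=C1CC[C@H]2C(C)(C)CCC[C@]2(C)[C@H]1CC/C(C)=C/Cc1c(O)cc2oc(-c3ccc(O)cc3)c(O)c(=O)c2c1O` likewise reaches only a limit of this assay, > 100000 nM.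

For the measured compounds named here, compound 1 thus stands alone as the single compound with a number in this assay, while the other two sit at the limit of > 100000 nM in this assay, at which 2 of the 3 values shown sit. Compound 4 `CCCCCCCC/C=C\CCCCCCCCc1c(O)cc(O)c(C(C)=O)c1O` keeps the core of compound 1 and differs in one place: dec-1-en-1-yl in place of decyl on a saturated chain carbon, eight bonds along the chain from an aromatic carbon. Going by the values given here, no measured pair differs by only this change, so the step can be judged from the change alone. The expected step from compound 1 to compound 4 in this assay is small, within the usual scatter, and written as a 1.3-fold lower number from compound 1 to compound 4 (0.10 log units; within the scatter). Compound 4 is therefore estimated at 22000 nM, with a range from 7000 nM to 70000 nM.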

Compound 4, half-maximal inhibitory concentration: > 100000 nM
Compound 4: only a limit was reported; the forecaster's own chance of this, stated with the estimate: 10%; at least 4.5-fold (0.65 log units) between middle value and limit.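

A single double bond on a saturated chain carbon, eight bonds along the chain from an aromatic carbon, changes the result in this assay: dec-1-en-1-yl in place of decyl gives an at least 3.5-fold higher number from compound 1 to compound 4 (0.55 log units; beyond the scatter). For the compounds shown here, this is the first pair differing in one place, so it is the first sign that this part of the chain matters on the shared core. The true size of the step stays unknown, since compound 4 gives only a limit of the assay: the limit of > 100000 nM in this assay, at which 3 of the 4 values shown sit.

On these data alone, whether a shorter chain, or a chain ending in an amine or a carboxylic acid, would give a lower number than compound 1 remains open. This one pair also leaves open whether moving the double bond along the chain would change the result.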